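The compounds below may be only part of what the source reports. "The series", "measured", "known", "first", "only" and "open" are said of these compounds alone.

Compound 3 `COc1ccc(-c2nn(-c3ccccc3)cc2C(=O)/C=C\Nc2ccc(Cl)cc2)cc1` is the reference point here. In a functional assay on HT-29 cells (Homo sapiens) for antiproliferative activity, read by MTT assay, with a stated time of 48 h (a higher number here means a weaker inhibitor, a lower number a stronger inhibitor), compound 3 gives 4760 nM, the second highest of the three numbers measured. Among the measured compounds shown here, its nearest neighbour is compound 1 `O=C(/C=C\Nc1ccc(Cl)cc1)c1cn(-c2ccccc2)nc1-c1ccc(F)cc1`, which in this assay gives 4600 nM; the step of a 1.0-fold higher number from compound 1 to compound 3 (0.01 log units; within the scatter) is the one measured single change, a methoxy in place of a fluoro on an aromatic carbon. Furthest away is compound 2 `COc1cc(N/C=C\C(=O)c2cn(-c3ccccc3)nc2-c2ccc(F)cc2)cc(OC)c1OC`, which in this assay gives 7770 nM.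

Compound 4 `COc1ccc(-c2nn(-c3ccccc3)cc2C(=O)/C=C\Nc2cc(OC)c(OC)c(OC)c2)cc1` differs from compound 3 by 3,4,5-trimethoxyphenyl in place of 4-chlorophenyl on an amine nitrogen. For the measured compounds named here, no measured step covers exactly this swap, but compounds 1 and 2 carry the same two groups on the same nitrogen against a fluoro-bearing core, and their values differ only a little. The corresponding step from compound 3 is therefore expected to be small and upward, quite possibly not beyond the scatter, with the estimated step of a 1.6-fold higher number from compound 3 to compound 4 (0.21 log units; within the scatter). On this basis compound 4 is expected to give 7800 nM in this assay, within a range from 3500 nM to 17000 nM.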

Compound 4, half-maximal inhibitory concentration: 14600 nM
Beside the measured number, compound 4's estimate is 1.9-fold (0.27 log units) below it, within the range that was stated.
By their numbers in this assay, from the lowest: compounds 1, 3, 2 and 4 (each within the scatter of the next, the first and the last beyond it).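

In this assay, the exchange of 4-chlorophenyl for 3,4,5-trimethoxyphenyl on the amine nitrogen now has a measured step of its own, a 3.1-fold higher number from compound 3 to compound 4 (0.49 log units; beyond the scatter), a modest change beyond the scatter. With the fluoro-bearing core, the same two groups give 4600 nM for compound 1 and 7770 nM for compound 2. Methoxy in place of fluoro on an aromatic carbon gives a 1.9-fold higher number from compound 2 to compound 4 (0.27 log units; within the scatter), so this change stays within the scatter with either group on the nitrogen, and its two readings agree: the same change on two cores in this assay, a 1.0-fold higher number (0.01 log units; within the scatter) from compound 1 to compound 3 and a 1.9-fold higher number (0.27 log units; within the scatter) from compound 2 to compound 4, 1.8-fold (0.26 log units) apart, within the scatter of two such steps.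

The compounds shown carry only these two groups on the nitrogen, so the effect of the chlorine cannot be separated from that of the three methoxy groups. Going by these compounds, how a benzyl or cyclohexyl group on this nitrogen would compare remains open.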